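Carbamoyl for acetoxymethyl: outlook on tolerated concentration

The source may hold more compounds than are shown below. What is called first, only, known or untested is meant among the compounds shown, and "the series" means these compounds.

Compound 1 `CC(=O)OCc1cccc2c1CCOC2=O` gives > 2430000 nM in an ADME assay on HepG2 2.2.15 cells (Homo sapiens) for cytotoxicity, read by MTT assay, with a stated time of 72 h (a lower number here means that less compound is tolerated, a higher number that more compound is tolerated), and this is a limit of the assay.
Compound 2 `O=C1OCCc2c(COC(=O)C3CCCCC3)cccc21` gives > 1840000 nM in this assay, again a limit of the assay.

Compound 1 therefore stands only at a limit in this assay. Among the measured compounds shown here, the one further value shown is also a limit, so neither compound has a number to rank it by; the two limits are the limit of > 2430000 nM in this assay, at which 1 of the 2 values shown sits, and (the limit of > 1840000 nM in this assay, at which 1 of the 2 values shown sits).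

Compound 3 `NC(=O)c1cccc2c1CCOC2=O` is not yet measured. It differs from compound 1 in one place: carbamoyl in place of acetoxymethyl on an aromatic carbon. For the measured compounds named here, the only measured step is a step that the two limits leave unreadable from compound 1 to compound 2, which exchanges the alkyl on the ester carbonyl and is unreadable between two limits; it gives no size for any step, and no other pair touches the carbamoyl change. Nothing measured here sets an expectation of a step beyond the scatter in this assay in either direction. Compound 3 is expected to sit at a limit once more, estimated as 2000000 nM with a range from 500000 nM to 5000000 nM. The step this estimate means, an at least 1.2-fold lower number from compound 1 to compound 3 (0.08 log units; that floor lies within the scatter), is expected to be no more than the scatter.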

Compound 3, half-maximal cytotoxic concentration: > 3290000 nM
Compound 3: a limit, no number (the forecaster's own chance of this, stated with the estimate: 80%); at least 1.6-fold (0.21 log units) between middle value and limit.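

Compound 1 and compound 3 both stand only at limits in this assay, and the step between them for carbamoyl in place of acetoxymethyl cannot be read. The compounds shown leave open at what concentration compound 1, compound 2 or compound 3 reaches half-maximal cytotoxicity in this assay, and whether either exchange shifts that concentration at all.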